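Repeating One Change to Estimate a Fourth Compound

A few compounds are considered here, and "the series" means these few. Any claim that something is new, unique, unknown or untested is made for them only; others in the source may bear on it.

Compound 1, `COc1cc(/C=C2\CN(S(=O)(=O)c3ccc(F)cc3)C/C(=C\c3ccccc3F)C2=O)cc(OC)c1OC`, gives 7940 nM in a functional assay on HepG2 cells (Homo sapiens) for cytotoxicity, read by MTT assay, with a stated time of 24 h; on this read-out higher numbers stand for weaker inhibition and lower numbers for stronger inhibition.
Compound 2, `COc1cc(/C=C2\CN(S(=O)(=O)c3ccc(F)cc3)C/C(=C\c3cccc([N+](=O)[O-])c3)C2=O)cc(OC)c1OC`, gives 3250 nM in this assay.
Compound 3, `COc1cc(/C=C2\CN(S(=O)(=O)c3ccc(NC(C)=O)cc3)C/C(=C\c3ccccc3F)C2=O)cc(OC)c1OC`, gives 4750 nM in this assay.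

The three measured compounds share one core and differ in two places. From compound 1 to compound 2 the change is 3-nitrophenyl in place of 2-fluorophenyl on a double-bonded chain carbon bound to a double-bonded ring carbon, and the result is a 2.4-fold lower number from compound 1 to compound 2 (0.39 log units; beyond the scatter). The cores of compound 1 and compound 3 differ by acetamido in place of fluoro on an aromatic carbon, which gave a 1.7-fold lower number from compound 1 to compound 3 (0.22 log units; within the scatter), so this second change is not clearly seen in the read-out.

Compound 4, `COc1cc(/C=C2\CN(S(=O)(=O)c3ccc(NC(C)=O)cc3)C/C(=C\c3cccc([N+](=O)[O-])c3)C2=O)cc(OC)c1OC`, has not yet been measured in this assay. It differs from compound 3 by 3-nitrophenyl in place of 2-fluorophenyl on a double-bonded chain carbon bound to a double-bonded ring carbon, the same change, at the same described place, as that between compound 1 and compound 2. Assuming that step carries over, compound 4 is expected to move a 2.4-fold lower number from compound 3 to compound 4 (0.38 log units; beyond the scatter) from compound 3, resting on a 2.4-fold lower number from compound 1 to compound 2 (0.39 log units; beyond the scatter). The estimate for compound 4 is therefore 2000 nM, with a likely range from 1000 nM to 4200 nM.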

Compound 4, half-maximal inhibitory concentration: 3340 nM
Compound 4: the middle estimate sits 1.7-fold (0.22 log units) below what was measured; low and high end bracket the measured number.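

In this assay, 3-nitrophenyl in place of 2-fluorophenyl, now on the core that carries acetamido, gives a 1.4-fold lower number from compound 3 to compound 4 (0.15 log units; within the scatter), and acetamido in place of fluoro, now on the core that carries 3-nitrophenyl, gives a 1.0-fold higher number from compound 2 to compound 4 (0.01 log units; within the scatter). The 3-nitrophenyl change stands beyond the scatter on one core and within it on the other, yet its two steps cannot be told apart, so it neither clearly keeps its full size nor clearly loses it: the same change on two cores in this assay, a 2.4-fold lower number (0.39 log units; beyond the scatter) from compound 1 to compound 2 and a 1.4-fold lower number (0.15 log units; within the scatter) from compound 3 to compound 4, 1.7-fold (0.23 log units) apart, within the scatter of two such steps The acetamido change also shows no sign of depending on the core, although a single pair of cores cannot show that the two changes act independently across the series: the same change on two cores in this assay, a 1.7-fold lower number (0.22 log units; within the scatter) from compound 1 to compound 3 and a 1.0-fold higher number (0.01 log units; within the scatter) from compound 2 to compound 4, 1.7-fold (0.23 log units) apart, within the scatter of two such steps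

The compounds shown leave open how these steps would behave with other groups, such as an amine or a carboxylic acid in place of acetamido, or a nitrile in place of the nitro group. They also leave open whether any such replacement would give a step clearly beyond the scatter on both cores.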